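Swapping amino for fluoro on compound 2

A few compounds are considered here, and "the series" means these few. Any claim that something is new, unique, unknown or untested is made for them only; others in the source may bear on it.

Measured so far in a physicochemical assay for lipophilicity, using the shake flask method; a higher number here means a more lipophilic compound, a lower number a more polar compound

Compound 1 `Cc1c(/C=C/C(=O)O)cnc2ccc(O[C@@H](C)c3c(Cl)ccc(F)c3Cl)cc12` gives 3
Compound 2 `C[C@H](Oc1ccc2ncc(/C=C/C(=O)O)c(C3CC3)c2c1)c1c(Cl)ccc(N)c1Cl` gives 2.8

Compound 2 (2.8) and compound 1 (3) lie within the usual scatter of each other, so these two numbers cannot be told apart. Compound 3 `C[C@H](Oc1ccc2ncc(/C=C/C(=O)O)c(C3CC3)c2c1)c1c(Cl)ccc(F)c1Cl` has fluoro in place of amino on an aromatic carbon, with the rest of compound 2 unchanged. Within the data shown here, no measured pair isolates this swap, so what follows is a judgement based on the structural change. Compound 1 also carries fluoro and stands at 3 on the same scale, which offers only a rough anchor. In this assay a moderate rise beyond the scatter is expected, an estimated a number 0.70 log units higher from compound 2 to compound 3 (beyond the scatter) in all. Compound 3 is therefore expected at about 3.5 (estimated range 3.1 to 3.9).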

Compound 3, distribution coefficient: 4.1
For compound 3 the middle estimate is 0.60 log units below the measured one, outside the stated range (above it).
By their numbers in this assay, from the lowest: compounds 2 and 1 (each within the scatter of the next); then compound 3.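

In this assay, fluoro in place of amino on this aromatic carbon gives a number 1.30 log units higher from compound 2 to compound 3 (beyond the scatter), the first measured size for a change made at this position alone. Cyclopropyl in place of methyl, a change in a different place, gives a number 1.10 log units higher from compound 1 to compound 3 (beyond the scatter), so each of these two places carries a large step of its own, something the closeness of the numbers for compound 1 and compound 2 did not reveal. Nothing measured here explains why either step is so large.

Going by these compounds, whether the fluoro step keeps its size with methyl in place of cyclopropyl remains open. Also open, on these data alone, is what a hydroxyl or a methoxy group would give on the same aromatic carbon, and so whether the step belongs to fluoro, to amino, or to both.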